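The source may hold more compounds than are shown below. What is called first, only, known or untested is meant among the compounds shown, and "the series" means these compounds.

Measured compounds in a functional assay on CHO cells for agonist activity at Free fatty acid receptor 2 (Homo sapiens), read by cAMP accumulation; on this read-out lower numbers stand for smaller maximal responses and higher numbers for larger maximal responses:
Compound 1 `CC(C)[C@H](C(=O)Nc1ccccc1)c1ccc(Cl)cc1`: < 30%, a limit of the assay rather than a number.
Compound 2 `CC(C)C(C(=O)Nc1nnn[nH]1)c1ccc(Cl)cc1`: < 30%, likewise only a limit.

Compound 1 thus stands at the floor of what can be reported, and the same holds for every value shown: the limit of < 30% in this assay, at which 2 of the 2 values shown sit. Compound 3 `CC(C)[C@H](C(=O)Nc1cnns1)c1ccc(Cl)cc1` differs from compound 1 by 1,2,3-thiadiazol-5-yl in place of phenyl on an amide-type nitrogen. Among the compounds with values here, no step between measured compounds exists to guide the size of this change, and compound 2 shows that another replacement on the amide-type nitrogen still sat at the limit. Compound 3 is therefore expected to stay low, with an expected step that the limit leaves unreadable from compound 1 to compound 3 in this assay that lies within the scatter. The estimate for compound 3 is 20%, expected between 5% and 45%.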

Compound 3, largest response reached (reported as efficacy), in percent of the reference or control that the assay uses: 48%
Compound 3: the middle estimate sits 28 percentage points below what was measured, and the stated range ends below it.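

In this assay, 1,2,3-thiadiazol-5-yl in place of phenyl on the amide-type nitrogen gives a number at least 18 percentage points higher from compound 1 to compound 3 (beyond the scatter). So the group at this place can lift the response clear of the limit, which the earlier compounds did not show. The true size of the step stays unknown, because compound 1 offers only a limit as its starting point: the limit of < 30% in this assay, at which 2 of the 3 values shown sit.

This single change alters ring size and hetero atoms together, so it leaves open whether the sulfur, the nitrogens or the smaller ring matters. Going by these compounds, whether a thiazol-2-yl or pyridin-2-yl ring would serve equally well also remains open.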